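The source may report more compounds than this note shows. Statements on the series, on what has been measured and on what is new or still open speak of the compounds shown alone.

Notes on the series. In a functional assay on the whole organism with Mus musculus as the target (on this read-out higher numbers stand for an effect only at larger amounts of compound and lower numbers for an effect already at smaller amounts), compound 1 `CCN(C)C(=O)/C=C1\CCc2c(F)cc(F)cc21` gives 56 mg/kg, the lowest of the three numbers in hand, though the other two stand within its scatter. Compound 2 `NC(=O)/C=C1\CCc2cc(F)c(F)cc21` gives 64 mg/kg and compound 3 `CCN(C)C(=O)/C=C1\CCc2ccc(F)cc21` gives 100 mg/kg; neither number can be told apart from that of compound 1 beyond the usual repeat-to-repeat spread. Going by the values given here, the only step between measured compounds that differ in one place is a 1.8-fold higher number from compound 1 to compound 3 (0.25 log units; within the scatter), a change at an aromatic carbon, and it says nothing about the amide end of the molecule.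

Compound 4 `O=C(/C=C1\CCc2c(F)cc(F)cc21)NC1CC1` has not been measured. It differs from compound 1 as follows: cyclopropylamino in place of ethyl(methyl)amino on a carbonyl carbon. Among the compounds with values here, no measured step bears on this change. Within the data shown here, compound 2 carries both a different amide and a different fluorine pattern than compound 1, so its value shows only that two changes taken together left the number close to that of compound 1; it is not a single step and cannot be read as one. With nothing in hand that speaks to the amide alone, no step beyond the scatter is expected in this assay in either direction. The estimate for compound 4 is accordingly 60 mg/kg, with a range from 30 mg/kg to 120 mg/kg. The expected step of a 1.1-fold higher number from compound 1 to compound 4 (0.03 log units; within the scatter) lies within the scatter.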

Compound 4, dose for half-maximal effect: 62 mg/kg
Estimate against measurement, compound 4: 1.0-fold (0.01 log units) below; the range from low to high includes it.
By their numbers in this assay, from the lowest: compounds 1, 4, 2 and 3 (each within the scatter of the next).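

In this assay the amide end now has its first single step: a 1.1-fold higher number from compound 1 to compound 4 (0.04 log units; within the scatter) stays within the scatter. On a carbonyl carbon, then, cyclopropylamino can stand in place of ethyl(methyl)amino with the fluorine pattern of compound 1 held fixed, and bringing in a three-membered ring and the amide hydrogen gives no readable change in the dose. This is a cleaner reading than compound 2 could offer, as that compound changes the amide and the fluorine pattern together, though the finding rests on this one pair alone and no measurement in hand gives a reason for it.

As far as these compounds go, whether the same holds for groups further from these two on the carbonyl carbon stays open, for instance morpholino, phenylamino or a longer chain such as octylamino, or a chain ending in a carboxylic acid. Also open, from the compounds shown here alone, is whether cyclopropylamino behaves the same way on the fluorine pattern of compound 3, since the step seen here comes from a single pattern.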